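Swapping the ring substituent: compound 3 to compound 4

This account rests on a few compounds, and the source may have more. Where it says the series, first, only, none or still open, it means among the compounds named here.

Compound 3 `O=c1ccoc2cc(OCc3cn(Cc4ccccc4Cl)nn3)ccc12` reaches only a limit in a functional assay on HeLa cells (Homo sapiens) for cytotoxicity, read by MTT assay, with a stated time of 48 h (a higher number here means a weaker inhibitor, a lower number a stronger inhibitor), where compound 3 gives > 100000 nM. Compound 2 `O=c1ccoc2cc(OCc3cn(Cc4cccc(Cl)c4)nn3)ccc12` likewise reaches a limit, giving > 100000 nM in this assay. Of the three measured compounds, only compound 1 `O=c1ccoc2cc(OCc3cn(Cc4ccc(Cl)cc4)nn3)ccc12` yields a number in this assay, 37600 nM. The steps of an at least 2.6-fold higher number from compound 1 to compound 2 (0.42 log units; beyond the scatter) and an at least 2.6-fold higher number from compound 1 to compound 3 (0.42 log units; beyond the scatter) both move the chlorine around the ring and both point toward weaker inhibition; the pair a step that the two limits leave unreadable from compound 2 to compound 3 cannot be read, as the limit of > 100000 nM in this assay, at which 2 of the 3 values shown sit, shows. Compound 4 `O=c1ccoc2cc(OCc3cn(Cc4ccc([N+](=O)[O-])cc4)nn3)ccc12` arises through (4-nitrophenyl in place of 2-chlorophenyl on a saturated chain carbon bound to an aromatic nitrogen). Among the measured compounds shown here, no measured step exchanges one group for another in this way, so the expectation rests mainly on compound 1, whose 4-chlorophenyl gave a number where the other two did not. Compound 4 is therefore estimated at 60000 nM in this assay, between 20000 nM and 200000 nM. The expected step is an at least 1.6-fold lower number from compound 3 to compound 4 (0.22 log units; that floor lies within the scatter), with a real chance that only a limit is reported.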

Compound 4, half-maximal inhibitory concentration: 25700 nM
The estimate for compound 4 lay 2.3-fold (0.37 log units) above the measured number; the measured number falls inside the stated range.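

The 4-nitrophenyl group shows that a second substituted phenyl at this place, on a saturated chain carbon bound to an aromatic nitrogen, can give a measured number in this assay, and the change is readable as an at least 3.8-fold lower number from compound 3 to compound 4 (0.59 log units; beyond the scatter) and as an at least 3.8-fold lower number from compound 2 to compound 4 (0.59 log units; beyond the scatter). Both sizes are only floors, as compound 2 and compound 3 each stop at a limit: the limit of > 100000 nM in this assay, at which 2 of the 4 values shown sit. Nitro in place of chloro on an aromatic carbon gives a 1.5-fold lower number from compound 1 to compound 4 (0.17 log units; within the scatter), so compound 1 and compound 4 cannot be told apart in this assay.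

As far as these compounds go, whether 2-nitrophenyl or 3-nitrophenyl would also stop at a limit, as their chlorine counterparts do, remains open. So does the result of placing an amine or a carboxylic acid on the phenyl ring.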